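Swapping the Amide Ring in a Cathepsin S Carbamate Series

This account rests on a few compounds, and the source may have more. Where it says the series, first, only, none or still open, it means among the compounds named here.

Going by the values given here, compound 2 `C[C@@H](CN1CC(C)(C)c2cc(F)ccc21)NC(=O)O[C@@H](CC1CCCCC1)C(=O)N1CCCC1` gives 56 nM in an assay on isolated protein for inhibition of cathepsin S (Homo sapiens) (on this read-out lower numbers stand for stronger inhibition and higher numbers for weaker inhibition), the lowest of the two numbers so far; its only neighbour, compound 1 `COCCN(C)C(=O)[C@H](CC1CCCCC1)OC(=O)N[C@@H](C)CN1CC(C)(C)c2cc(F)ccc21`, gives 172 nM. Among the compounds with values here, the one measured step, a 3.1-fold lower number from compound 1 to compound 2 (0.49 log units; beyond the scatter), shows that the group on this carbonyl carbon can shift the number modestly. Compound 3 `C[C@@H](CN1CC(C)(C)c2cc(F)ccc21)NC(=O)O[C@@H](CC1CCCCC1)C(=O)N1CCN(S(C)(=O)=O)CC1` carries 4-(methylsulfonyl)piperazin-1-yl in place of pyrrolidin-1-yl on a carbonyl carbon. Within the data shown here, no measured pair covers this exact swap, so only a small change is expected, perhaps a modest rise, a 2.1-fold higher number from compound 2 to compound 3 (0.33 log units; beyond the scatter). Compound 3 is therefore expected to give 120 nM, within 40 nM to 400 nM.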

Compound 3, inhibition constant: 1080 nM
Compound 3: middle estimate off by 9.0-fold (0.95 log units), on the low side, outside the stated range (above it).
By their numbers in this assay, from the lowest: compound 2; then compound 1; then compound 3.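

In this assay the 4-(methylsulfonyl)piperazin-1-yl group on this carbonyl carbon gives a 19-fold higher number from compound 2 to compound 3 (1.29 log units; beyond the scatter) and also a 6.3-fold higher number from compound 1 to compound 3 (0.80 log units; beyond the scatter) when set against the open-chain amide. The group at this place can therefore move the number much further than the first step showed. No measurement available here explains the change. From the compounds shown here alone, it stays open whether the methylsulfonyl part or the six-membered ring goes with the higher number. A plain piperidin-1-yl or morpholin-4-yl group on the same carbonyl carbon would help separate the two.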